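The source may report more compounds than this note shows. Statements on the series, on what has been measured and on what is new or still open speak of the compounds shown alone.

Working notes on the series. Three measured compounds share one core and differ only in the group on the amide carbonyl carbon. In an assay on isolated protein for inhibition of Rho-associated protein kinase 1 (Homo sapiens), read by scintillation counting, radiometric assay and 33P incorporation, with a stated time of 40 min, in the presence of a further agent that is not named here (a higher number here means a weaker inhibitor, a lower number a stronger inhibitor), compound 1 `CCCC(=O)Nc1cccc(NC(=O)COc2ccc3c(=O)ccoc3c2)c1`, which carries a propyl there, gives 1430 nM. Compound 2 `O=C(COc1ccc2c(=O)ccoc2c1)Nc1cccc(NC(=O)c2ccc(F)cc2)c1`, with a 4-fluorophenyl in its place, gives 129 nM in this assay. Compound 3 `O=C(COc1ccc2c(=O)ccoc2c1)Nc1cccc(NC(=O)c2ccc(Br)cc2)c1`, with a 4-bromophenyl, gives 303 nM in this assay. The two aryl amides sit well apart from the propyl amide: an 11-fold lower number from compound 1 to compound 2 (1.04 log units; beyond the scatter) and a 4.7-fold lower number from compound 1 to compound 3 (0.67 log units; beyond the scatter). Between the aryl amides the gap is smaller: a 2.3-fold higher number from compound 2 to compound 3 (0.37 log units; beyond the scatter). Compound 3 thus stands second of the three numbers, with compound 2 nearest and compound 1 furthest.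

Compound 4 `CCOc1ccc(C(=O)Nc2cccc(NC(=O)COc3ccc4c(=O)ccoc4c3)c2)cc1` is not yet measured. Relative to compound 3 the change is ethoxy in place of bromo on an aromatic carbon. Within the data shown here, no measured step covers an ethoxy. Among the measured compounds shown here, the only step at the same aromatic carbon, the exchange of fluoro for bromo, was modest, and both aryl amides lie far from compound 1, so the aryl amide level is expected to persist. For compound 4 the expected step is a 1.0-fold lower number from compound 3 to compound 4 (0.00 log units; within the scatter) in this assay. The estimate for compound 4 in this assay is 300 nM, within a range from 100 nM to 900 nM.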

Compound 4, half-maximal inhibitory concentration: 17 nM
The estimate for compound 4 lay 18-fold (1.25 log units) above the measured number; measured number outside the range, below it.
By their numbers in this assay, from the lowest: compound 4; then compound 2; then compound 3; then compound 1.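

In this assay, the group on the aromatic carbon para to a large group proves a far stronger handle than the halogen exchange alone suggested: against a 2.3-fold higher number from compound 2 to compound 3 (0.37 log units; beyond the scatter), ethoxy gives an 18-fold lower number from compound 3 to compound 4 (1.25 log units; beyond the scatter) and a 7.6-fold lower number from compound 2 to compound 4 (0.88 log units; beyond the scatter), so the aryl amides do not share a single level. The change puts ethoxy, with three heavy atoms and one hydrogen-bond acceptor, where each halogen is a single atom with no acceptor, and it yields the lowest number of the series, with an 84-fold lower number from compound 1 to compound 4 (1.92 log units; beyond the scatter) across the full exchange on the carbonyl carbon. Nothing available bears on why ethoxy has this effect on the number.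

The compounds shown do not separate the contribution of the ether oxygen from that of the two-carbon chain, a question that methoxy, propoxy and a plain ethyl group at the same carbon would address. Also open, going by these compounds, is whether the trend extends to a longer alkoxy chain or whether a hydroxyl or an amine at this carbon would keep the number of compound 4, 17 nM.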